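A few compounds are considered here, and "the series" means these few. Any claim that something is new, unique, unknown or untested is made for them only; others in the source may bear on it.

Compound 2 `Cc1ccsc1/C=C(/SCc1ccccc1F)C(=O)c1ccc(Cl)cc1` gives 50000 nM in a functional assay on DU-145 cells (Homo sapiens) for inhibition, read by trypan blue exclusion, with a stated time of 96 h (on this read-out lower numbers stand for stronger inhibition of growth and higher numbers for weaker inhibition of growth), the highest of the three numbers here, though compound 1 `Cc1ccc(/C=C(\C(=O)c2ccc([N+](=O)[O-])cc2)S(=O)(=O)Cc2ccc(Cl)cc2)s1`, at 25000 nM, sits within the scatter of it. Compound 3 `COc1ccccc1/C=C(/SCc1ccccc1F)C(=O)c1ccc(Cl)cc1` gives 10000 nM, and a 5.0-fold lower number from compound 2 to compound 3 (0.70 log units; beyond the scatter).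

Compound 4 `Cc1ccsc1/C=C(/SCc1ccc(F)cc1)C(=O)c1ccc(Cl)cc1` differs from compound 2 in one place: 4-fluorophenyl in place of 2-fluorophenyl on a saturated chain carbon bound to a sulfur. Going by the values given here, the single measured step, from compound 2 to compound 3, alters a different part of the shared core, so no measured step bears directly on moving the fluorine within the fluorobenzyl group. With nothing to point either way, the expectation is a step in this assay no larger than the scatter, so that compound 4 is estimated at 50000 nM, in a range of 15000 nM to 150000 nM, meaning an expected no change at the digits printed from compound 2 to compound 4 (within the scatter).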

Compound 4, concentration for 50% growth inhibition: 50000 nM
Compound 4: the middle estimate sits on the measured number at the digits printed; the measured number falls inside the stated range.
By their numbers in this assay, from the lowest: compound 3; then compounds 1, 2 and 4 (each within the scatter of the next).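

In this assay, the change from 2-fluorobenzyl to 4-fluorobenzyl gives no change at the digits printed from compound 2 to compound 4 (within the scatter). Going by these compounds alone, this is the first reading at this group on the saturated chain carbon bound to a sulfur, since the earlier step changed a different part of the shared core, and it shows that this one move of the fluorine does not shift the number beyond the scatter. No evidence here bears on this result. Still open, from the compounds shown here alone, is whether an amine or a methoxy group in place of the fluorine would shift the number, and whether the same move would read alike on compound 3.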